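Bromo to trifluoromethyl: working notes on compound 3

A few compounds are considered here, and "the series" means these few. Any claim that something is new, unique, unknown or untested is made for them only; others in the source may bear on it.

Values in a functional assay on HepG2 cells (Homo sapiens) for cytotoxicity, with a stated time of 24 h; a lower number here means a stronger inhibitor, a higher number a weaker inhibitor:
compound 1 `COc1cc(Cl)ccc1C(=S)Nc1ccc(Cl)cc1O` gives 5110 nM
compound 2 `COc1cc(Cl)ccc1C(=S)Nc1ccc(Br)cc1O` gives 3880 nM

For the measured compounds named here, compound 2 lies within the scatter of compound 1, and these are the only two numbers so far. Compound 3 `COc1cc(Cl)ccc1C(=S)Nc1ccc(C(F)(F)F)cc1O` differs from compound 2 by trifluoromethyl in place of bromo on an aromatic carbon. Going by the values given here, the one measured step that bears on this is bromo in place of chloro on an aromatic carbon, a 1.3-fold lower number from compound 1 to compound 2 (0.12 log units; within the scatter). That step involves no trifluoromethyl, so it is only a loose guide. No shift beyond the scatter is expected in this assay, in either direction. The expected step is a 1.0-fold higher number from compound 2 to compound 3 (0.01 log units; within the scatter). The estimated value for compound 3 is 4000 nM, with an expected range of 1800 nM to 9000 nM.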

Compound 3, half-maximal inhibitory concentration: 3140 nM
The estimate for compound 3 lay 1.3-fold (0.11 log units) above the measured number; the measured number falls inside the stated range.
By their numbers in this assay, from the lowest: compounds 3, 2 and 1 (each within the scatter of the next).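

In this assay trifluoromethyl in place of bromo gives a 1.2-fold lower number from compound 2 to compound 3 (0.09 log units; within the scatter) and in place of chloro gives a 1.6-fold lower number from compound 1 to compound 3 (0.21 log units; within the scatter) at this position, meta to a hydroxy group. A group of four heavy atoms therefore reads the same here as a single halogen, and chloro, bromo and trifluoromethyl cannot be told apart at this position. No measurement in hand accounts for this flat response.

On these data alone, whether an amine, a carboxylic acid or a longer chain here would move the number beyond the scatter stays open. So does the contribution of the hydroxy group itself.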